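A few compounds are considered here, and "the series" means these few. Any claim that something is new, unique, unknown or untested is made for them only; others in the source may bear on it.

Measured so far in a functional assay on HeLa cells (Homo sapiens) for cytotoxicity, read by MTT assay, with a stated time of 24 h; a lower number here means a stronger inhibitor, a higher number a weaker inhibitor:

compound 1, `COc1cc(/C=C2\CN(C)C/C(=C\c3ccc(Cl)cc3Cl)C2=O)cc(OC)c1`, gives 7760 nM
compound 2, `COc1cc(/C=C2\CN(C)C/C(=C\c3ccc(Cl)c(Cl)c3)C2=O)cc(OC)c1`, gives 6900 nM
compound 3, `CN1C/C(=C\c2cccc([N+](=O)[O-])c2)C(=O)/C(=C/c2ccc(Cl)cc2Cl)C1`, gives 8900 nM

Compound 4, `CN1C/C(=C\c2cccc([N+](=O)[O-])c2)C(=O)/C(=C/c2ccc(Cl)c(Cl)c2)C1`, has not yet been tested in this assay. It is made from compound 3 by one change: 3,4-dichlorophenyl in place of 2,4-dichlorophenyl on a double-bonded chain carbon bound to a double-bonded ring carbon. The same change turns compound 1 into compound 2, and there it made a 1.1-fold lower number from compound 1 to compound 2 (0.05 log units; within the scatter). Compound 1 and compound 3 share only part of their structure; how their two cores differ is not broken down here, so the change is carried over from one core to the other.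

Given that, the step from compound 3 to compound 4 is expected to be about as small, a 1.1-fold lower number from compound 3 to compound 4 (0.05 log units; within the scatter), because the measured step was a 1.1-fold lower number from compound 1 to compound 2 (0.05 log units; within the scatter). Compound 4 is therefore estimated at 8000 nM, likely between 4000 nM and 16000 nM.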

Compound 4, half-maximal inhibitory concentration: 9120 nM
Estimate against measurement, compound 4: 1.1-fold (0.06 log units) below, and the stated range covers the measured number.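

Putting 3,4-dichlorophenyl in place of 2,4-dichlorophenyl on the core of compound 3 leaves no readable change in this assay (a 1.0-fold higher number from compound 3 to compound 4 (0.01 log units; within the scatter)). The two cores agree on this change: the same change on two cores in this assay, a 1.1-fold lower number (0.05 log units; within the scatter) from compound 1 to compound 2 and a 1.0-fold higher number (0.01 log units; within the scatter) from compound 3 to compound 4, 1.2-fold (0.06 log units) apart, within the scatter of two such steps. This shows that, on these two cores, the change carries over as a step too small to read, but two such small steps cannot show that a larger effect would carry over, or that the same would hold on any other core.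

The compounds shown leave open what a single chlorine or a pyridine ring would do in place of the dichlorophenyl group. They also leave open whether the step stays this small on a core bearing an amine or a carboxylic acid on its other aromatic ring.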